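Nucleoside series, cytotoxicity screen: from compound 1 to compound 4

This account rests on a few compounds, and the source may have more. Where it says the series, first, only, none or still open, it means among the compounds named here.

Compound 1 `CC(=O)OC[C@H]1O[C@@H](n2cc(-c3cn(Cc4ccccc4)nn3)c(=O)[nH]c2=O)C[C@@H]1OC(C)=O` gives 102% in a functional assay on MDA-MB-231 cells (Homo sapiens) for cytotoxicity, read by sulforhodamine B assay, tested at 10 uM; a lower number here means less inhibition, a higher number more inhibition at the concentration tested (going by the name of the read-out). Compound 3 `CC(C)(C)c1ccc(-c2cc(-c3cn([C@H]4C[C@H](O)[C@@H](CO)O4)c(=O)[nH]c3=O)on2)cc1` gives 102%, level with compound 1 at the digits shown, and together they are the highest of the three numbers. Compound 2 `CCCCCCCCc1cc(-c2cn([C@H]3C[C@H](O)[C@@H](CO)O3)c(=O)[nH]c2=O)on1` gives 96.7%, within the scatter of compound 1. For the measured compounds named here, the only measured step, a number 5.3 percentage points higher from compound 2 to compound 3 (within the scatter), lies within the scatter. Compound 4 `CC(=O)OC[C@H]1O[C@@H](n2cc(-c3cn(Cc4ccc(C(C)C)cc4)nn3)c(=O)[nH]c2=O)C[C@@H]1OC(C)=O` is not yet measured; it differs from compound 1 by isopropyl in place of hydrogen on an aromatic carbon. Going by the values given here, the one available step also exchanged a substituent and moved the read-out by no more than the scatter, and all three numbers sit level with one another, so for compound 4 no step beyond the scatter is expected in this assay. Compound 4 is estimated at 100%, between 88% and 110%, an expected step of a number 2 percentage points lower from compound 1 to compound 4 (within the scatter).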

Compound 4, a percentage reported as inhibition, at one concentration (the size of the read-out at that concentration, not a potency): 98.1%
Beside the measured number, compound 4's estimate is 1.9 percentage points above it, and the stated range covers the measured number.
By their numbers in this assay, from the lowest: compounds 2, 4, 1 and 3 (each within the scatter of the next).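

In this assay, going from benzyl to 4-isopropylbenzyl gives a number 3.9 percentage points lower from compound 1 to compound 4 (within the scatter), so added carbon bulk para to a large group on the six-membered aromatic ring leaves the read-out within the scatter, at a place the earlier step did not touch. No measurement available here explains this flat result. With all the numbers from a single concentration level with one another, the screen does not separate these compounds. Open, going by these compounds, is whether a carboxylic acid or an amine at this same place would move the read-out beyond the scatter.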